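Sulfamoyl to amino on the shared core: cytotoxicity outlook

The compounds below may be only part of what the source reports. "The series", "measured", "known", "first", "only" and "open" are said of these compounds alone.

Compound 1 `Cc1cc(CCC#N)cc(C)c1Oc1cc(Nc2ccc(C#N)cc2)c(N)cc1S(N)(=O)=O` is one of three compounds that have been run in an ADME assay on TZM cells (Homo sapiens) for cytotoxicity, read by XTT assay, with a stated time of 4 days (a higher number here means that more compound is tolerated, a lower number that less compound is tolerated), so far; in this assay compound 1 gives 11100 nM. The companions are compound 2 `Cc1cc(/C=C/C#N)cc(C)c1Oc1cc(Nc2ccc(C#N)cc2)c(N)cc1CO`, which gives 16300 nM, and compound 3 `Cc1cc(/C=C/C#N)cc(C)c1Oc1cc(Nc2ccc(C#N)cc2)c(N)cc1C(=O)O`, which gives 14900 nM. All three numbers lie within the scatter of one another, so compound 1 is not separated from either neighbour on this read-out.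

Among the measured compounds shown here, only one measured step joins two compounds that differ in a single place: a 1.1-fold lower number from compound 2 to compound 3 (0.04 log units; within the scatter). That step alters a group at the same position of the core that is varied here, but it exchanges carboxy for hydroxymethyl and says nothing about the sulfamoyl group itself.

Compound 4 `Cc1cc(CCC#N)cc(C)c1Oc1cc(Nc2ccc(C#N)cc2)c(N)cc1N` differs from compound 1 by amino in place of sulfamoyl on an aromatic carbon. For the measured compounds named here, no measured step covers this exchange. What the series shows is that every change tried at this position, including the step from compound 2 to compound 3, has stayed within the scatter, and that compound 1 gives 11100 nM in the same band as its companions. A step beyond the scatter is therefore not expected in this assay in either direction; the expected step is a 1.1-fold higher number from compound 1 to compound 4 (0.03 log units; within the scatter). Compound 4 is estimated at 12000 nM, with a range from 5000 nM to 30000 nM.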

Compound 4, half-maximal cytotoxic concentration: > 25000 nM
Compound 4 gave a limit, no number (the forecaster's own chance of this, stated with the estimate: 20%); middle value at least 2.0-fold (0.31 log units) away from the limit.
By their numbers in this assay, from the lowest: compounds 1, 3 and 2 (each within the scatter of the next). At a limit, above all of these: compound 4.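

In this assay, among the compounds shown here, amino in place of sulfamoyl gives an at least 2.2-fold higher number from compound 1 to compound 4 (0.35 log units; beyond the scatter), the first step at this position of the shared core to lie beyond the scatter. The earlier exchange of hydroxymethyl for carboxy gave only a 1.1-fold lower number from compound 2 to compound 3 (0.04 log units; within the scatter), so it could not show that this position is able to move the tolerated concentration at all; the sulfamoyl to amino change now shows that it can. Compound 4 gives > 25000 nM, which is a limit of the assay and not a number, and the step from it can be read only as a lower bound because of that limit: the limit of > 25000 nM in this assay, at which 1 of the 4 values shown sits.

From the compounds shown here alone, the size of the step stays open, as does whether it comes from the loss of sulfamoyl or from the entry of amino, since only these two groups are compared on the core of compound 1. A methylsulfonyl group, a carboxamide, a methylamino group or plain hydrogen at the same place would help separate the two, and amino on the core of compound 2 would test whether the change carries over to the other chain.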